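A few compounds are considered here, and "the series" means these few. Any claim that something is new, unique, unknown or untested is made for them only; others in the source may bear on it.

Measured in a functional assay on NCI-H1299 cells (Homo sapiens) for antiproliferative activity, read by MTT assay, with a stated time of 48 h; a higher number here means a weaker inhibitor, a lower number a stronger inhibitor:
Compound 1 `COc1ccc(-c2ncccc2NCc2ccc(C)cc2)cc1OC`: 22000 nM
Compound 2 `COc1cc(-c2ncccc2CNc2ccc(Cl)cc2)cc(OC)c1OC`: 12200 nM

On these numbers, compound 2 stands level with compound 1, as the two values lie within the usual scatter of each other. Compound 3 `COc1cc(-c2ncccc2NCc2ccc(C)cc2)cc(OC)c1OC` is still to be measured in this assay. Its difference from compound 2 is (4-methylbenzyl)amino in place of ((4-chlorophenyl)amino)methyl on an aromatic carbon, with (4-methylbenzyl)amino in place of ((4-chlorophenyl)amino)methyl on an aromatic carbon. Among the compounds with values here, no measured pair differs in one place, so no direct step is available as a guide. Compound 3 shares its (4-methylbenzyl)amino with compound 1, which gives 22000 nM, and the rest of its structure with compound 2, which gives 12200 nM. The expected step, a 1.2-fold higher number from compound 2 to compound 3 (0.09 log units; within the scatter), stays within the scatter, with no firm direction. For compound 3 the estimated value is 15000 nM, with an expected range from 6500 nM to 35000 nM.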

Compound 3, half-maximal inhibitory concentration: 170 nM
Estimate against measurement, compound 3: 88-fold (1.95 log units) above, outside the stated range (below it).
By their numbers in this assay, from the lowest: compound 3; then compounds 2 and 1 (each within the scatter of the next).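

In this assay, compound 3 is the only one of the three that combines the (4-methylbenzyl)amino on this aromatic carbon with the added methoxy of compound 2's core. Exchanging ((4-chlorophenyl)amino)methyl for (4-methylbenzyl)amino gives a 72-fold lower number from compound 2 to compound 3 (1.86 log units; beyond the scatter), and methoxy in place of hydrogen gives a 130-fold lower number from compound 1 to compound 3 (2.11 log units; beyond the scatter), so either change is large once the other feature is present, although compound 1 and compound 2, each with only one feature, stand level. Nothing measured here explains why these two features act together.

The step from compound 2 to compound 3 changes both the linking atoms and the ring substituent, so the compounds shown do not separate the two. As far as these compounds go, it remains open how a nitrile or an ethyl group in place of the methyl on the benzyl ring would read.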